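Thiophene in Place of Aminophenyl on a Chalcone Scaffold

This account rests on a few compounds, and the source may have more. Where it says the series, first, only, none or still open, it means among the compounds named here.

The measured compounds and their values in a functional assay on SK-BR-3 cells (Homo sapiens) for antiproliferative activity, read by XTT assay, with a stated time of 72 h; on this read-out lower numbers stand for stronger inhibition and higher numbers for weaker inhibition:
compound 1, `COc1ccc(-c2cc3ccccc3nc2/C=C/C(=O)c2ccccc2)cc1`, gives 700 nM;
compound 2, `COc1ccc(C(=O)/C=C/c2nc3ccccc3cc2-c2ccc(OC)cc2)cc1`, gives 9280 nM;
compound 3, `COc1ccc(-c2cc3ccccc3nc2/C=C/C(=O)c2ccc(N)cc2)cc1`, gives 8560 nM.

Compound 3 stands second highest of the three numbers; its value and that of compound 2 lie within the scatter of each other, while compound 1 sits far lower, with a 12-fold higher number from compound 1 to compound 3 (1.09 log units; beyond the scatter) separating them. Compound 4, `COc1ccc(-c2cc3ccccc3nc2/C=C/C(=O)c2ccsc2)cc1`, has not been measured in this assay. It differs from compound 3 by thiophen-3-yl in place of 4-aminophenyl on a carbonyl carbon. Among the compounds with values here, two measured steps bear on this change, both at the ring on the carbonyl carbon: a 13-fold higher number from compound 1 to compound 2 (1.12 log units; beyond the scatter) and a 12-fold higher number from compound 1 to compound 3 (1.09 log units; beyond the scatter). Both added a group to the unsubstituted ring of compound 1 and both gave large increases. Within the data shown here, compound 4 removes the amino group of compound 3 and exchanges the ring itself, for which no measured pair gives guidance. A move back toward the number of compound 1 is expected, but with broad uncertainty because a 12-fold higher number from compound 1 to compound 3 (1.09 log units; beyond the scatter) shows how strongly this position responds. The step is estimated as a 5.7-fold lower number from compound 3 to compound 4 (0.76 log units; beyond the scatter). Compound 4 is expected to give 1500 nM, within 400 nM to 6000 nM.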

Compound 4, half-maximal inhibitory concentration: 660 nM
Estimate against measurement, compound 4: 2.3-fold (0.36 log units) above, and the stated range covers the measured number.
By their numbers in this assay, from the lowest: compounds 4 and 1 (each within the scatter of the next); then compounds 3 and 2 (each within the scatter of the next).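

In this assay, within the data shown here, the ring on the carbonyl carbon could be exchanged without moving the number, something no earlier compound could show: thiophen-3-yl in place of phenyl gives a 1.1-fold lower number from compound 1 to compound 4 (0.03 log units; within the scatter). Against the two substituted rings the gap is wide, with a 13-fold lower number from compound 3 to compound 4 (1.11 log units; beyond the scatter) and a 14-fold lower number from compound 2 to compound 4 (1.15 log units; beyond the scatter), so among these four compounds the unsubstituted phenyl and thiophen-3-yl rings give the low numbers, while 4-aminophenyl and 4-methoxyphenyl give the high numbers. Nothing available accounts for this split.

Open, from the compounds shown here alone, is whether the low number would hold with a methyl or chloro group on the thiophen-3-yl ring. Also open, going by these compounds, is what a thiophen-2-yl ring, or a non-aromatic cyclohexyl group, would give on the same carbonyl carbon.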